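A Pyridinyl Swap Carried Onto a Second Core

A few compounds are considered here, and "the series" means these few. Any claim that something is new, unique, unknown or untested is made for them only; others in the source may bear on it.

Compound 1 `CO[C@@H]1CC=C2NN(c3cc(Cl)cc(Cl)c3)C(=O)C[C@]2(C)O1` and compound 2 `CO[C@@H]1CC=C2NN(c3cc(Cl)cc(Cl)c3)C(=O)C[C@]2(c2ccncc2)O1` share one core. In a functional assay on A549 cells (Homo sapiens) for inhibition, read by sulforhodamine B assay, with a stated time of 48 h (on this read-out lower numbers stand for stronger inhibition and higher numbers for weaker inhibition), compound 1 gives 17500 nM, and compound 2 gives 7500 nM. The change between them, (pyridin-4-yl in place of methyl on a saturated ring carbon), produced a 2.3-fold lower number from compound 1 to compound 2 (0.37 log units; beyond the scatter). Compound 3 `COc1cc(OC)cc(N2NC3=CC[C@@H](OC)O[C@@]3(C)CC2=O)c1` rests on a different core; how its core differs from that of compound 1 is not broken down here. In this assay compound 3 gives 6150 nM, a number within the scatter of compound 2 and beyond the scatter from compound 1.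

Compound 4 `COc1cc(OC)cc(N2NC3=CC[C@@H](OC)O[C@@]3(c3ccncc3)CC2=O)c1` is the untested partner of compound 3, obtained by pyridin-4-yl in place of methyl on a saturated ring carbon. This is the same kind of change as that between compound 1 and compound 2, though the surroundings read differently: in compound 2 the site lies on a six-membered non-aromatic ring with one oxygen, next to the ring oxygen, whereas in compound 4 it lies on a six-membered non-aromatic ring with two nitrogen. The expectation for the new pair rests on a 2.3-fold lower number from compound 1 to compound 2 (0.37 log units; beyond the scatter). For compound 4 in this assay a step of about a 2.1-fold lower number from compound 3 to compound 4 (0.31 log units; beyond the scatter) is expected. Compound 4 is therefore estimated at 3000 nM, between 1200 nM and 7500 nM.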

Compound 4, half-maximal inhibitory concentration: 6220 nM
For compound 4 the middle estimate is 2.1-fold (0.32 log units) below the measured one, within the range that was stated.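

In this assay, pyridin-4-yl in place of methyl on a saturated ring carbon gave a 1.0-fold higher number from compound 3 to compound 4 (0.00 log units; within the scatter), so on this core the change produced no step beyond the scatter, unlike on the core of compound 1. Even so, the two steps cannot be told apart: the same change on two cores in this assay, a 2.3-fold lower number (0.37 log units; beyond the scatter) from compound 1 to compound 2 and a 1.0-fold higher number (0.00 log units; within the scatter) from compound 3 to compound 4, 2.4-fold (0.37 log units) apart, within the scatter of two such steps The result therefore gives no firm sign that the core alters the effect of this change, but it does not show that the effect carries over either, as each core contributes only a single pair of compounds.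

The compounds shown leave open whether a phenyl ring, a longer alkyl chain, an amine or a carboxylic acid on that saturated ring carbon would give a step beyond the scatter on either core in this assay. They also leave open whether the two steps would stay this close on further cores, or in cell lines other than the one used here.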